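Replacing the sulfinyl arm of compound 1 with an aminophenyl sulfide

The source may report more compounds than this note shows. Statements on the series, on what has been measured and on what is new or still open speak of the compounds shown alone.

Measured so far:
compound 1 `COc1ccc(CCCCCCCCOc2ccc(C[S+]([O-])c3ccccc3)nc2/C=C/C(=O)O)cc1`, 37 nM
compound 2 `COc1ccc(CCCCCCOc2ccc(CC(O)c3cccc(C(=O)O)c3)nc2/C=C/C(=O)O)cc1`, 165 nM
compound 3 `COc1ccc(CCCCCCCCOc2ccc(C[S+]([O-])c3cccc(CS(=O)(=O)C(F)(F)F)c3)nc2/C=C/C(=O)O)cc1`, 225 nM

In an assay for binding affinity to leukotriene B4 receptor 1 (Homo sapiens) (on this read-out lower numbers stand for stronger inhibition and higher numbers for weaker inhibition), compound 1 gives 37 nM, the lowest of the three numbers, with compound 2 at 165 nM and compound 3 at 225 nM; both gaps lie beyond the scatter. Compound 4 `COc1ccc(CCCCCCCCOc2ccc(CSc3cccc(N)c3)nc2/C=C/C(=O)O)cc1` is not yet measured. It differs from compound 1 by a group of 8 heavy atoms (6 carbon, 1 nitrogen, 1 sulfur; one six-membered aromatic ring of carbon only) in place of a group of 8 heavy atoms (6 carbon, 1 oxygen, 1 sulfur; one six-membered aromatic ring of carbon only), on a saturated chain carbon bound to an aromatic carbon.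

Among the measured compounds shown here, only one measured step bears on this change: a 6.1-fold higher number from compound 1 to compound 3 (0.78 log units; beyond the scatter), where a group was added to the same aromatic ring on compound 1. For the measured compounds named here, the change to compound 4 also adds a group to that ring, while the sulfur is no longer oxidised; no measured pair covers that second part, and compound 2 carries a different arm altogether, so its value only shows that another arm on this core is weaker than compound 1. A modest weakening is therefore expected, a 2.4-fold higher number from compound 1 to compound 4 (0.39 log units; beyond the scatter), with a wide range. Compound 4 is estimated at 90 nM, between 25 nM and 350 nM.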

Compound 4, inhibition constant: 34 nM
Compound 4: the middle estimate sits 2.6-fold (0.42 log units) above what was measured; the measured number falls inside the stated range.
By their numbers in this assay, from the lowest: compounds 4 and 1 (each within the scatter of the next); then compounds 2 and 3 (each within the scatter of the next).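

In this assay the exchange of arms gives a 1.1-fold lower number from compound 1 to compound 4 (0.04 log units; within the scatter), so (3-aminophenyl)sulfanyl on a saturated chain carbon bound to an aromatic carbon cannot be told apart from the arm of compound 1. Among the compounds shown here, the only earlier change on this ring, a 6.1-fold higher number from compound 1 to compound 3 (0.78 log units; beyond the scatter), might have suggested that added groups are poorly tolerated here, yet compound 4 shows that a ring bearing an amine, on an arm with an unoxidised sulfur, can keep a number like that of compound 1. The data offer no explanation for this result.

The compounds shown do not separate the added amine from the loss of the sulfinyl oxygen, since both changes occur together in compound 4. Going by these compounds, an unsubstituted phenylsulfanyl arm, a sulfinyl arm bearing the same amine, and a carboxylic acid in place of the amine remain open.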